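Adding a cyano group to the phenyl of compound 2

The source may report more compounds than this note shows. Statements on the series, on what has been measured and on what is new or still open speak of the compounds shown alone.

Measured so far:
Compound 1 `N=c1oc2ccc(Br)cc2cc1C(=O)NCC(O)CO` gives 11%.
Compound 2 `COc1cccc2cc(C(=O)Nc3c(C#N)ncn3-c3ccccc3)c(=N)oc12` gives 33%.
Compound 3 `COc1cccc2cc(C(=O)NCCCOCCCCOCCCNC(=O)c3cc4cccc(OC)c4oc3=N)c(=N)oc12` gives 30%.

In an assay on CHO cells for displacement of a labelled ligand from adenosine receptor A1 (Homo sapiens), read by scintillation counting, with a stated time of 60 min, tested at 10 uM (on this read-out higher numbers stand for more inhibition at the one concentration tested (going by the name of the read-out) and lower numbers for less inhibition), compound 2 stands at the highest of the three numbers shown, but compound 3 sits within the usual scatter of it, so the two cannot be told apart; only compound 1 lies beyond the scatter, well below. Compound 4 `COc1cccc2cc(C(=O)Nc3c(C#N)ncn3-c3ccc(C#N)cc3)c(=N)oc12` is the new compound, and it differs from compound 2 by cyano in place of hydrogen on an aromatic carbon. Within the data shown here, no pair of measured compounds differs in one place, so nothing here shows how such a change shifts this assay. I therefore expect no step beyond the scatter, with the estimated change from compound 2 to compound 4 being no change at the digits printed from compound 2 to compound 4 (within the scatter). For compound 4 the estimated value is 33%, ranging from 15% to 52%.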

Compound 4, a percentage reported as inhibition, at one concentration (the size of the read-out at that concentration, not a potency): 18%
Estimate against measurement, compound 4: 15 percentage points above, within the range that was stated.
By their numbers in this assay, from the lowest: compounds 1 and 4 (each within the scatter of the next); then compounds 3 and 2 (each within the scatter of the next).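

In this assay, putting cyano in place of hydrogen on the phenyl, para to a large group, gives a number 15 percentage points lower from compound 2 to compound 4 (beyond the scatter), a modest step but one beyond the scatter. Among these compounds, this is the first comparison in the set between compounds that differ in one place, and it shows that this aromatic carbon is not indifferent to what it carries. No measurement at hand gives a reason for the step.

On these data alone, whether any group at this carbon would lower the number, or cyano in particular, stays open. An amine or a carboxylic acid in the same place could settle that.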